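The source may report more compounds than this note shows. Statements on the series, on what has been measured and on what is new or still open speak of the compounds shown alone.

Compound 1, `O=C(CN1CCN(C(=O)c2cccc(Br)c2)CC1)N1CCN(CCCc2c[nH]c3ccccc23)CC1`, gives 80700 nM in an ADME assay on HEK293 cells (Homo sapiens) for cytotoxicity, read by MTT assay, with a stated time of 72 h; a higher number here means a weaker inhibitor, a lower number a stronger inhibitor.
Compound 2, `O=C(CN1CCN(C(=O)c2cccc(F)c2)CC1)N1CCN(CCCc2c[nH]c3ccccc23)CC1`, gives 182000 nM in this assay.
Compound 3, `O=C(CN1CCN(C(=O)c2ccccc2F)CC1)N1CCN(CCCc2c[nH]c3ccccc23)CC1`, gives 133000 nM in this assay.

Among these three, compound 2 carries the highest number, though a 1.4-fold lower number from compound 2 to compound 3 (0.14 log units; within the scatter) stays within the scatter, so only a 2.3-fold higher number from compound 1 to compound 2 (0.35 log units; beyond the scatter) sets it apart. Compound 4, `COc1ccc2[nH]cc(CCCN3CCN(C(=O)CN4CCN(C(=O)c5cccc(F)c5)CC4)CC3)c2c1`, has not yet been measured. It differs from compound 2 in one place: methoxy in place of hydrogen on an aromatic carbon. Among the compounds with values here, none of the measured steps bears on this end of the molecule. All three vary the halogenated ring on the carbonyl carbon, and the largest of them, a 2.3-fold higher number from compound 1 to compound 2 (0.35 log units; beyond the scatter), is merely modest, while a 1.6-fold higher number from compound 1 to compound 3 (0.22 log units; within the scatter) and a 1.4-fold lower number from compound 2 to compound 3 (0.14 log units; within the scatter) sit within the scatter. Within the data shown here, with no precedent for a change on the 1H-indol-3-yl portion and only small movements elsewhere, no step beyond the scatter is expected in this assay in either direction. The expected step is a 1.2-fold lower number from compound 2 to compound 4 (0.08 log units; within the scatter). Compound 4 is therefore estimated at 150000 nM, with a likely range from 70000 nM to 320000 nM.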

Compound 4, half-maximal inhibitory concentration: > 200000 nM
Compound 4 was reported as a limit (the forecaster's own chance of this, stated with the estimate: 25%); middle value at least 1.3-fold (0.12 log units) from the limit.
By their numbers in this assay, from the lowest: compounds 1, 3 and 2 (each within the scatter of the next, the first and the last beyond it). At a limit, above all of these: compound 4.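

Compound 4 gives > 200000 nM in this assay, which is a limit and not a number. It carries the only change shown on the 1H-indol-3-yl end of the molecule, and methoxy in place of hydrogen there does not bring the number down: the step reads an at least 1.0-fold higher number from compound 2 to compound 4 (0.04 log units; that floor lies within the scatter). That floor lies within the scatter, so the result shows no lowering at this position, but it cannot tell a real rise from no change, and the size of any rise cannot be read from a limit: the limit of > 200000 nM in this assay, at which 1 of the 4 values shown sits.

The compounds shown leave open whether a hydroxyl, a chlorine or an amine on this same aromatic carbon would move the number. They also leave open whether methoxy would act alike in the 3-bromophenyl setting of compound 1.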